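The source may hold more compounds than are shown below. What is called first, only, known or untested is meant among the compounds shown, and "the series" means these compounds.

Measured so far:
compound 1 `C=CCOC(=O)Nc1ccc([Se]C#N)cc1`, 17600 nM
compound 2 `CCCCOC(=O)Nc1ccc([Se][Se]c2ccc(NC(=O)OCCCC)cc2)cc1`, 28600 nM
compound 3 `O=C(Nc1ccc([Se][Se]c2ccc(NC(=O)Oc3ccccc3)cc2)cc1)Oc1ccccc1`, 5300 nM

All three were tested in a functional assay on PC-3 cells (Homo sapiens) for cytotoxicity, read by MTT assay, with a stated time of 72 h; on this read-out higher numbers stand for weaker inhibition of growth and lower numbers for stronger inhibition of growth. Compound 1 stands second highest of the three numbers; its value and that of compound 2 lie within the usual scatter of each other, while compound 3 gives a clearly lower number than compound 1, beyond the scatter. Compound 4 `CC(C)COC(=O)Nc1ccc([Se]C#N)cc1` has not yet been measured. It differs from compound 1 in one place: isopropyl in place of vinyl on a saturated chain carbon bound to an oxygen next to a carbonyl group. Read one bond further out, allyl becomes isobutyl. Within the data shown here, compounds 2 and 3 differ from compound 1 in more than this one place, so no measured pair shows what such a change does here. In this assay compound 4 is expected to give 14000 nM, with a range from 5000 nM to 40000 nM. This means an expected step of a 1.3-fold lower number from compound 1 to compound 4 (0.10 log units; within the scatter), small and not beyond the scatter.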

Compound 4, concentration for 50% growth inhibition: 21600 nM
Estimate against measurement, compound 4: 1.5-fold (0.19 log units) below, within the range that was stated.
By their numbers in this assay, from the lowest: compound 3; then compounds 1, 4 and 2 (each within the scatter of the next).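

In this assay, replacing allyl with isobutyl on the carbamate oxygen gives a 1.2-fold higher number from compound 1 to compound 4 (0.09 log units; within the scatter). Among these compounds, this is the first pair here that differs in one place, and it shows that at this place a chain with a double bond and a branched saturated chain give values within the scatter of each other. Nothing available explains this result.

From the compounds shown here alone, whether a longer chain would also stay within the scatter remains open. So does the effect of a chain ending in an amine or a carboxylic acid at this place.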